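The source may hold more compounds than are shown below. What is called first, only, known or untested is meant among the compounds shown, and "the series" means these compounds.

Measured so far in a functional assay on A549 cells (Homo sapiens) for cytotoxicity, read by MTT assay, with a stated time of 48 h; a lower number here means a stronger inhibitor, a higher number a weaker inhibitor:
- compound 1 `COc1cc(-c2nnc(SCC(=O)c3ccc(Cl)cc3)n2N2C(=O)c3ccccc3C2=O)cc(OC)c1OC`: 9030 nM
- compound 2 `COc1cc(-c2nnc(SCC(=O)c3ccc(C)cc3)n2N2C(=O)c3ccccc3C2=O)cc(OC)c1OC`: 6760 nM
- compound 3 `COc1cc(-c2nnc(SCC(=O)c3ccccc3)n2N2C(=O)c3ccccc3C2=O)cc(OC)c1OC`: > 200000 nM, which is a limit of the assay and not a number

Compound 3 stands apart from the other two in this assay: it sits at the limit of > 200000 nM in this assay, at which 1 of the 3 values shown sits, so only a range is known for it. Between compound 1 and compound 2 the step is a 1.3-fold lower number from compound 1 to compound 2 (0.13 log units; within the scatter), so the chloro and the methyl at that carbon cannot be told apart on these numbers. Removing either group to leave hydrogen is a different matter: an at least 22-fold higher number from compound 1 to compound 3 (1.34 log units; beyond the scatter) and an at least 29-fold higher number from compound 2 to compound 3 (1.47 log units; beyond the scatter), both well beyond the scatter.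

Compound 4 `COc1ccc(C(=O)CSc2nnc(-c3cc(OC)c(OC)c(OC)c3)n2N2C(=O)c3ccccc3C2=O)cc1` differs from compound 3 by methoxy in place of hydrogen on an aromatic carbon. The change puts a small group back at the same aromatic carbon that carries chloro in compound 1 and methyl in compound 2, so the two large steps to compound 3 are the ones that bear on it, read in reverse. A methoxy group has not been measured in this series, so its exact size is uncertain, but a step down of the same order is expected. For compound 4 the expected step is an at least 13-fold lower number from compound 3 to compound 4 (1.12 log units; beyond the scatter) in this assay. Compound 4 is accordingly estimated at 15000 nM, with a range from 4000 nM to 200000 nM.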

Compound 4, half-maximal inhibitory concentration: 30000 nM
The estimate for compound 4 lay 2.0-fold (0.30 log units) below the measured number, and the stated range covers the measured number.
By their numbers in this assay, from the lowest: compounds 2 and 1 (each within the scatter of the next); then compound 4. At a limit, above all of these: compound 3.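

In this assay, methoxy at this carbon, para to a large group, gives a measured number where hydrogen gave none: an at least 6.6-fold lower number from compound 3 to compound 4 (0.82 log units; beyond the scatter). Compound 3 is held at a limit and not a number, so that step gives only a minimum size: the limit of > 200000 nM in this assay, at which 1 of the 4 values shown sits. Methoxy is also the first group at this carbon to separate from the others, with a 4.4-fold higher number from compound 2 to compound 4 (0.65 log units; beyond the scatter) and a 3.3-fold higher number from compound 1 to compound 4 (0.52 log units; beyond the scatter), both beyond the scatter, whereas chloro and methyl could not be told apart; the three substituted compounds therefore do not sit on one level, although all three give lower numbers than the unsubstituted compound 3.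

On these data alone, what sets the order among the groups at this carbon stays open, and these compounds cannot settle it: a fluoro group, an amine, a carboxylic acid or a longer chain such as butoxy at the same carbon would widen the comparison. Also open, as far as these compounds go, is whether any group at another carbon of this ring can match the chloro and methyl compounds, as every substituted compound here carries its group at the one position.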